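Gastric fluid half-life: propyl ester replacing the amino acid amide

The source may hold more compounds than are shown below. What is called first, only, known or untested is meant among the compounds shown, and "the series" means these compounds.

Measured compounds:
- compound 1, `CCOc1cc(NC(=O)C2(NC(=O)c3ccc4c(C5CCCC5)c(-c5ncc(Cl)cn5)n(C)c4c3)CCC2)ccc1/C=C/C(=O)N[C@@H](CCC(=O)O)C(N)=O`, in an ADME assay on stomach for pharmacokinetics, in simulated gastric fluid (on this read-out lower numbers stand for a shorter-lived compound and higher numbers for a longer-lived compound), compound 1 gives 0.533 h
- compound 2, `CCOc1cc(NC(=O)C2(NC(=O)c3ccc4c(C5CCCC5)c(-c5ncc(Cl)cn5)n(C)c4c3)CCC2)ccc1/C=C/C(=O)N[C@@H](CCCNC(=N)N)C(N)=O`, in this assay compound 2 gives 0.467 h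

Compound 2 holds the lowest of the two numbers; its nearest neighbour is compound 1, and the step of a 1.1-fold lower number from compound 1 to compound 2 (0.06 log units; within the scatter) lies within the scatter, so the two stand level on this read-out.

Compound 3, `CCCOC(=O)/C=C/c1ccc(NC(=O)C2(NC(=O)c3ccc4c(C5CCCC5)c(-c5ncc(Cl)cn5)n(C)c4c3)CCC2)cc1OCC`, is not yet measured. It differs from compound 2 as follows: a group of 4 heavy atoms (3 carbon, 1 oxygen; no ring) in place of a group of 12 heavy atoms (6 carbon, 5 nitrogen, 1 oxygen; no ring), on a carbonyl carbon. Among the compounds with values here, the only measured step, from compound 1 to compound 2, exchanges a group inside the part that leaves here and does not test removal of that part or entry of the propoxy group on the carbonyl carbon; it gave no shift beyond the scatter. Within the data shown here, no measured pair therefore bears directly on this change. With nothing to point either way, compound 3 is expected to stay near compound 2, with the step of a 1.1-fold higher number from compound 2 to compound 3 (0.03 log units; within the scatter) expected to lie within the scatter, but with a wide margin because the change is large. The estimate for compound 3 is 0.5 h, with a range from 0.2 h to 1.5 h.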

Compound 3, half-life: 2.23 h
The estimate for compound 3 lay 4.5-fold (0.65 log units) below the measured number; measured number above the stated range.
By their numbers in this assay, from the lowest: compounds 2 and 1 (each within the scatter of the next); then compound 3.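

In this assay, the position on the carbonyl carbon whose other neighbour is the double-bonded chain carbon proves responsive to the read-out: propoxy in place of the whole side chain gives (a 4.8-fold higher number from compound 2 to compound 3 (0.68 log units; beyond the scatter)) and, against the acid-bearing side chain (1-carbamoyl-3-carboxypropyl)amino, (a 4.2-fold higher number from compound 1 to compound 3 (0.62 log units; beyond the scatter)), both beyond the scatter and of similar size. The exchange inside the side chain moved nothing beyond the scatter, so the shift appears only when the side chain leaves as a whole and propoxy enters, and the identity of its end group is not what separates compound 3 from compound 1 and compound 2. No measurement available here accounts for the longer half-life.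

Removal of the side chain and entry of propoxy happen in the same step, so their shares in the shift remain unseparated. A free carboxylic acid, a simple primary amide, or an ethoxy or butoxy group on the same carbonyl carbon would show whether the higher number belongs to the propyl ester specifically or to any small group there.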